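The source may report more compounds than this note shows. Statements on the series, on what has been measured and on what is new or still open speak of the compounds shown alone.

Series notes. Compound 1 `Cc1ccc(-c2nn(-c3ccccc3)cc2-c2nc3ccccc3n2C(=O)c2ccccc2C)cc1`, compound 2 `Cc1ccc(-c2nn(-c3ccccc3)cc2-c2nc3ccccc3n2C(=O)c2ccccc2)cc1` and compound 3 `O=C(c1ccc(Cl)cc1)n1c(-c2cn(-c3ccccc3)nc2-c2ccc(C(F)(F)F)cc2)nc2ccccc21` share one core. In an ADME assay on HEK-293T cells (Homo sapiens) for cytotoxicity, read by MTT assay, with a stated time of 24 h (a higher number here means that more compound is tolerated, a lower number that less compound is tolerated), compound 1 gives 176000 nM, compound 2 gives 204000 nM and compound 3 gives 181000 nM. Compound 3 stands nearest compound 1 and furthest from compound 2, though all three numbers lie within the scatter of one another. Among the compounds with values here, the only measured one-place change is a 1.2-fold higher number from compound 1 to compound 2 (0.06 log units; within the scatter), which lies within the scatter. Compound 4 `Cc1ccc(-c2nn(-c3ccccc3)cc2-c2nc3ccccc3n2C(=O)c2ccc(Cl)cc2)cc1` differs from compound 3 by methyl in place of trifluoromethyl on an aromatic carbon. Within the data shown here, no measured step covers this exchange, so the measured data give no direction; a step within the scatter is expected. For compound 4 in this assay the expected value is 185000 nM, in the range 110000 nM to 300000 nM. This amounts to an expected step of a 1.0-fold higher number from compound 3 to compound 4 (0.01 log units; within the scatter).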

Compound 4, half-maximal cytotoxic concentration: 216000 nM
The estimate for compound 4 lay 1.2-fold (0.07 log units) below the measured number; the range from low to high includes it.
By their numbers in this assay, from the lowest: compounds 1, 3, 2 and 4 (each within the scatter of the next).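

Trifluoromethyl and methyl are exchanged directly here for the first time, as 4-(trifluoromethyl)phenyl to 4-methylphenyl: a 1.2-fold higher number from compound 3 to compound 4 (0.08 log units; within the scatter) in this assay and shows that this position accepts either group within the scatter. Chloro in place of hydrogen on an aromatic carbon gives a 1.1-fold higher number from compound 2 to compound 4 (0.02 log units; within the scatter) and also stays within the scatter, as does 4-chlorophenyl in place of 2-methylphenyl on the carbonyl carbon, with a 1.2-fold higher number from compound 1 to compound 4 (0.09 log units; within the scatter) as its step. No evidence is available that bears on these results.
Going by these compounds, whether an amine, a carboxylic acid or a longer chain at this position would move the number beyond the scatter remains open.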